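This account rests on a few compounds, and the source may have more. Where it says the series, first, only, none or still open, it means among the compounds named here.

Three carbamate- and thiourea-linked compounds share a diaryl-carbinol piperidine core and have been tested in a functional assay for antagonist activity at Neuropeptide Y receptor type 2 (Homo sapiens); on this read-out lower numbers stand for stronger inhibition and higher numbers for weaker inhibition. Compound 1 `CCN(CC)c1ccc(NC(=S)N2CCC(C(O)(c3ccccc3)c3ccccc3)CC2)cc1Cl` gives 85 nM in this assay. Compound 2 `CN(C)S(=O)(=O)c1ccc(NC(=S)N2CCC(C(O)(c3ccccc3)c3ccccn3)CC2)cc1` gives 98 nM in this assay. Compound 3 `O=C(Oc1ccc(S(=O)(=O)N2CCCC2)cc1)N1CCC(C(O)(c2ccccc2)c2ccccc2)CC1` gives 49 nM in this assay. The gaps from compound 3 to compound 1 and to compound 2 both lie within the usual scatter, so the three measured compounds cannot be separated from one another on these numbers.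

Compound 4 `CCN(CC)C(=O)c1ccc(OC(=O)N2CCC(C(O)(c3ccccc3)c3ccccc3)CC2)cc1` has not yet been measured. It differs from compound 3 in one place: diethylcarbamoyl in place of (pyrrolidin-1-yl)sulfonyl on an aromatic carbon. Going by the values given here, no measured pair shows this kind of exchange, so the size of the step cannot be read from data in hand. Because compound 3 gives 49 nM and the exchange keeps the rest of the molecule untouched, the expected step from compound 3 to compound 4 is a 1.4-fold higher number from compound 3 to compound 4 (0.15 log units; within the scatter), that is, no change beyond the scatter. Compound 4 is therefore estimated at 70 nM in this assay, with a range from 25 nM to 200 nM.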

Compound 4, half-maximal inhibitory concentration: 220 nM
Beside the measured number, compound 4's estimate is 3.1-fold (0.50 log units) below it; measured number outside the range, above it.
By their numbers in this assay, from the lowest: compounds 3, 1 and 2 (each within the scatter of the next); then compound 4.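

In this assay, putting diethylcarbamoyl in place of (pyrrolidin-1-yl)sulfonyl on an aromatic carbon, para to a large group, gives a 4.5-fold higher number from compound 3 to compound 4 (0.65 log units; beyond the scatter). This is the first exchange in one place among the compounds shown, and it shows that the number responds to what this position carries, a step beyond the scatter that the earlier compounds, with no such pair, could not reveal. Nothing at hand accounts for the step, which swaps a group with a five-membered ring and two double bonds for one with no ring and one double bond.

On these data alone, what a pyrrolidin-1-ylcarbonyl or a diethylsulfamoyl group would give at this place stays open, and with it whether the sulfonyl or the ring carries the difference. Also open, as far as these compounds go, is whether the same exchange would move the number on a thiourea-linked compound.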